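This account rests on a few compounds, and the source may have more. Where it says the series, first, only, none or still open, it means among the compounds named here.

Of the compounds shown here, two sharing one core have so far been tested in an assay on isolated protein for inhibition of thiosulfate sulfurtransferase (Homo sapiens), with a stated time of 60 min, in the absence of a further agent; on this read-out lower numbers stand for stronger inhibition and higher numbers for weaker inhibition. Compound 1, `O=C(Nc1ccc(Sc2nc3ccccc3s2)c(Cl)c1)c1cc(Br)cc(Br)c1`, gives > 100000 nM, which is a limit of the assay and not a number. Compound 2, `O=C(Nc1ccc(Sc2nc3ccccc3s2)c(Cl)c1)c1cccc(Br)c1`, gives > 100000 nM, again a limit rather than a number. The step that the two limits leave unreadable from compound 1 to compound 2 is therefore not readable in size or direction: both values sit at the limit of > 100000 nM in this assay, at which 2 of the 2 values shown sit, so the two compounds cannot be told apart on this read-out. Compound 3, `O=C(Nc1ccc(Sc2nc3ccccc3s2)c(Cl)c1)c1cc(Br)cc(Br)c1O`, has not yet been measured in this assay. It differs from compound 2 by 3,5-dibromo-2-hydroxyphenyl in place of 3-bromophenyl on a carbonyl carbon. Among the compounds with values here, only one measured step exists, and it is unreadable, so no measured step tells how this change should act in this assay; the two limits carry no usable size. The expectation for compound 3 thus rests on thin ground and is estimated at 50000 nM, with a likely range from 10000 nM to 200000 nM. This estimate means an expected step of an at least 2.0-fold lower number from compound 2 to compound 3 (0.30 log units; that floor lies within the scatter), with a real chance that only a limit is reported again.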

Compound 3, half-maximal inhibitory concentration: > 100000 nM
Compound 3 gave a limit, no number; the forecaster's own chance of this, stated with the estimate: 65%; at least 2.0-fold (0.30 log units) between middle value and limit.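

In this assay compound 3 gives > 100000 nM, again a limit of the assay and not a number. The steps among compound 1, compound 2 and compound 3 therefore cannot be read in size or direction: the limit of > 100000 nM in this assay, at which 3 of the 3 values shown sit.

The compounds shown leave open whether any change to the shared core gives a measurable value, and what the bromo and hydroxy groups contribute.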